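The compounds below may be only part of what the source reports. "The series", "measured", "known", "first", "only" and "open" are said of these compounds alone.

Compound 3 `COC(=O)CSc1c(O)cc(OC)c(C(=O)c2c(O)cc(C)cc2OC)c1C(=O)OC` stands only at a limit in a functional assay, with a stated time of 30 min; on this read-out lower numbers stand for stronger inhibition and higher numbers for weaker inhibition: compound 3 gives > 100000 nM, which is a limit of the measurement rather than a number. Compound 1 `COC(=O)c1c(C(=O)c2c(O)cc(C)cc2OC)c(OC)cc(O)c1[S@@+](C)[O-]` gives > 100000 nM, also a limit. Compound 2 `COC(=O)c1c(C(=O)c2c(O)cc(C)cc2OC)c(OC)cc(O)c1[S@+](C)[O-]` gives > 100000 nM, again a limit. Compound 4 `COC(=O)c1cc(O)cc(OC)c1C(=O)c1c(O)cc(C)cc1OC` differs from compound 3 by hydrogen in place of ((methoxycarbonyl)methyl)sulfanyl on an aromatic carbon. The measured steps that touch compound 3 are a step that the two limits leave unreadable from compound 1 to compound 3 and a step that the two limits leave unreadable from compound 2 to compound 3, and because of the limit of > 100000 nM in this assay, at which 3 of the 3 values shown sit, neither has a readable size, while the fact that compounds 1 and 2 differ only in the configuration as drawn leaves a step that the two limits leave unreadable from compound 1 to compound 2 equally silent. Within the data shown here, no measured step therefore points in any direction for compound 4, so compound 4 is expected, as a guess, to give 100000 nM, within 10000 nM to 300000 nM, a step of a number no higher from compound 3 to compound 4 (the limit leaves the size open).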

Compound 4, half-maximal inhibitory concentration: > 100000 nM
Compound 4: no number, only a limit (the forecaster's own chance of this, stated with the estimate: 70%); the middle value sits exactly at the limit.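

Compound 4 also stops at a limit, so its steps from compound 1, compound 2 and compound 3 cannot be read: the limit of > 100000 nM in this assay, at which 4 of the 4 values shown sit.

The compounds shown leave open what change to the shared core, if any, would give a measurable inhibition value.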